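A few compounds are considered here, and "the series" means these few. Any claim that something is new, unique, unknown or untested is made for them only; others in the source may bear on it.

Among the compounds with values here, compound 1 `Fc1ccc(-c2nn3c(NC4CCCC4)cccc3c2-c2ccc3[nH]ccc3c2)cc1` gives 20000 nM in an ADME assay on Vero cells (Chlorocebus sabaeus) for cytotoxicity (a higher number here means that more compound is tolerated, a lower number that less compound is tolerated), the only single number in this set. Compound 3 `Fc1ccc(-c2nn3c(NC4CCCC4)cccc3c2-c2cccnc2)cc1` reaches only a limit, > 40000 nM. Compound 2 `Cc1nc(-c2c(-c3ccc(F)cc3)nn3c(NC4CCCC4)cccc23)co1` has no result, "not determined" (no result reported). Within the data shown here, the one measured step that bears on the change is an at least 2.0-fold higher number from compound 1 to compound 3 (0.30 log units; that floor lies within the scatter), which runs up to the limit of > 40000 nM in this assay, at which 1 of the 3 values shown sits. Compound 4 `Nc1n[nH]cc1-c1c(-c2ccc(F)cc2)nn2c(NC3CCCC3)cccc12` differs from compound 1 by 3-amino-1H-pyrazol-4-yl in place of 1H-indol-5-yl on an aromatic carbon. That measured step and this change both remove the 1H-indol-5-yl group; the evidence is a single limit, and a shift toward more tolerated compound, or none beyond the scatter, is expected. The expected step is a 1.8-fold higher number from compound 1 to compound 4 (0.24 log units; within the scatter). Compound 4 is estimated at 35000 nM, between 15000 nM and 80000 nM.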

Compound 4, half-maximal cytotoxic concentration: 20000 nM
The estimate for compound 4 lay 1.8-fold (0.24 log units) above the measured number; the measured number falls inside the stated range.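

In this assay, the exchange of 1H-indol-5-yl for 3-amino-1H-pyrazol-4-yl on this aromatic carbon gives no change at the digits printed from compound 1 to compound 4 (within the scatter), so this position now has a second replacement for 1H-indol-5-yl with a firm reading. Against pyridin-3-yl, the same group gives an at least 2.0-fold lower number from compound 3 to compound 4 (0.30 log units; that floor lies within the scatter). That step is only a floor, set by the limit of compound 3: the limit of > 40000 nM in this assay, at which 1 of the 4 values shown sits.

Going by these compounds, how far compound 3 lies past its limit remains open. So does the effect of a piperidin-4-yl group or a carboxylic acid on this carbon.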